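This account rests on a few compounds, and the source may have more. Where it says the series, first, only, none or still open, it means among the compounds named here.

Of the compounds shown here, three that share one core have been measured in an assay on isolated protein for inhibition of Alpha glucosidase (Homo sapiens), with stated times of 5 min and 15 min, tested at 50 uM; a lower number here means less inhibition, a higher number more inhibition at the concentration tested (going by the name of the read-out). Compound 1 `Cc1ccc(/C=C2\CCC/C(=C\c3ccccc3)C2=O)cc1` gives 34.1% in this assay. Compound 3 `COc1cccc(/C=C2\CCC/C(=C\c3ccccc3)C2=O)c1OC` gives 31.8%, a number within the scatter of compound 1, so the two cannot be told apart. Compound 2 `O=C(C1=C(O)/C(=C/c2ccc(O)c(O)c2)CCC1)c1ccccc1` gives 55.9%, a higher number that lies beyond the scatter of compound 1. On the numbers seen so far, compound 1 sits together with compound 3, and only compound 2 stands apart from it.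

Compound 4 `O=C1/C(=C/c2ccccc2)CCC/C1=C\c1ccc(Br)cc1` has not yet been measured in this assay. It differs from compound 1 in one place: bromo in place of methyl on an aromatic carbon. For the measured compounds named here, no measured pair shows this particular change, so its effect cannot be read from the data. The step of a number 2.9 percentage points higher from compound 1 to compound 4 (within the scatter) is expected to be small, with no direction that goes beyond the scatter. Compound 4 is therefore estimated to give 37% in this assay, with a likely range from 22% to 54%.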

Compound 4, a percentage reported as inhibition, at one concentration (the size of the read-out at that concentration, not a potency): 29.1%
Beside the measured number, compound 4's estimate is 7.9 percentage points above it, and the stated range covers the measured number.
By their numbers in this assay, from the lowest: compounds 4, 3 and 1 (each within the scatter of the next); then compound 2.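

For the compounds shown here, replacing methyl with bromo on the aromatic carbon gives the only direct comparison at this position so far, with a number 5 percentage points lower from compound 1 to compound 4 (within the scatter) in this assay. At this concentration, the 4-methylphenyl and 4-bromophenyl versions of the shared core therefore cannot be told apart, so this single swap gives no sign that the position is sensitive to the change. No outside measurement is available to explain why these two groups read alike.

As far as these compounds go, it remains open whether an amine or a carboxylic acid at this position would move the number beyond the scatter. It is also unknown whether the same swap from methyl to bromo would give a similarly small step on a different compound in the series.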